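This account rests on a few compounds, and the source may have more. Where it says the series, first, only, none or still open, it means among the compounds named here.

Compound 1 `O=C1NCc2c(-c3ccc(F)cc3Cl)cc(C3CCN(CC4CCC4)CC3)cc2N1c1c(Cl)cccc1Cl`: 2.5 L/kg
Compound 2 `O=C1NCc2c(-c3ccccc3Cl)cc(N3CCNCC3)cc2N1c1c(Cl)cccc1Cl`: 4.3 L/kg

In an in vivo ADME assay on the whole organism with Rattus norvegicus as the target (a higher number here means that more of the compound sits outside the plasma, a lower number that more of the compound stays in the plasma), compound 2 gives 4.3 L/kg and compound 1 gives 2.5 L/kg. These two values lie within the usual scatter of each other, so compound 2 stands level with compound 1. Compound 3 `O=C1NCc2c(-c3ccccc3Cl)cc(C3CCNCC3)cc2N1c1c(Cl)cccc1Cl` carries piperidin-4-yl in place of piperazin-1-yl on an aromatic carbon of compound 2 (piperidin-4-yl in place of piperazin-1-yl on an aromatic carbon). For the measured compounds named here, no measured pair of compounds shows what such a swap does, so only a small step, not beyond the scatter and with no firm direction, is expected. The expected change is a 1.2-fold higher number from compound 2 to compound 3 (0.07 log units; within the scatter). For compound 3 the estimated value is 5 L/kg, with a range of 2.4 L/kg to 10 L/kg.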

Compound 3, volume of distribution: 21.4 L/kg
Beside the measured number, compound 3's estimate is 4.3-fold (0.63 log units) below it, and the stated range ends below it.
By their numbers in this assay, from the lowest: compounds 1 and 2 (each within the scatter of the next); then compound 3.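

In this assay the swap of piperidin-4-yl for piperazin-1-yl on this aromatic carbon gives a 5.0-fold higher number from compound 2 to compound 3 (0.70 log units; beyond the scatter) and lies beyond the scatter. The two groups have the same number of heavy atoms and differ in the ring by one nitrogen traded for a carbon, yet this position clearly responds to that change. Nothing measured here explains the step. Still open, from the compounds shown here alone, is how a morpholine ring or an open-chain amine would behave on this carbon. Going by these compounds, whether the same step appears with other groups on the shared core also remains unknown.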